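Carboxy added to the phenylsulfonyl group of compound 2

The source may hold more compounds than are shown below. What is called first, only, known or untested is meant among the compounds shown, and "the series" means these compounds.

Of the compounds shown here, two on the shared core have numbers so far. In a functional assay for inhibition, with Homo sapiens as the target (on this read-out higher numbers stand for weaker inhibition and lower numbers for stronger inhibition), compound 1 (`CCCCNS(=O)(=O)N[C@@H](CNC(=O)c1ccc2c(c1)C(=O)N(CCC1CCNCC1)C2)C(=O)O`) gives 19 nM and compound 2 (`O=C(NC[C@H](NS(=O)(=O)c1ccccc1)C(=O)O)c1ccc2c(c1)C(=O)N(CCC1CCNCC1)C2`) gives 8 nM as the lowest number of the pair. The next compound is compound 3 (`O=C(O)c1ccc(S(=O)(=O)N[C@@H](CNC(=O)c2ccc3c(c2)C(=O)N(CCC2CCNCC2)C3)C(=O)O)cc1`), in which phenylsulfonyl becomes (4-carboxyphenyl)sulfonyl and the rest stays unchanged. The change is carboxy in place of hydrogen on an aromatic carbon, para to a large group (carboxy in place of hydrogen on an aromatic carbon). For the measured compounds named here, one measured step bears on it, and only indirectly: a 2.4-fold lower number from compound 1 to compound 2 (0.38 log units; beyond the scatter) is modest and beyond the scatter, and it comes from phenyl in place of butylamino on a sulfonyl sulfur. Going by the values given here, no measured compound carries a substituent on that phenyl ring, so the direction of the new step is poorly defined. A small move towards a higher number is expected, with nothing beyond the scatter. The expected step is a 1.5-fold higher number from compound 2 to compound 3 (0.18 log units; within the scatter) in this assay on this reading. Compound 3 is estimated at 12 nM with an expected range from 4 nM to 40 nM as the working figure.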

Compound 3, half-maximal inhibitory concentration: 7 nM
For compound 3 the middle estimate is 1.7-fold (0.23 log units) above the measured one; low and high end bracket the measured number.
By their numbers in this assay, from the lowest: compounds 3 and 2 (each within the scatter of the next); then compound 1.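

In this assay, the only substituent shown so far on the phenyl ring of the sulfonyl group, a carboxy of 3 heavy atoms para to a large group, gives a 1.1-fold lower number from compound 2 to compound 3 (0.06 log units; within the scatter), so on this read-out the phenyl and 4-carboxyphenyl compounds cannot be told apart. The advantage over the butylamino group on the sulfonyl sulfur also holds with this substituent in place: 4-carboxyphenyl gives a 2.7-fold lower number from compound 1 to compound 3 (0.43 log units; beyond the scatter), a modest step that is beyond the scatter, as the phenyl step was. No supporting data accompany these results to explain why the added carboxy leaves the number within the scatter.

The compounds shown leave open whether this holds for the carboxy alone or for other groups at this ring position, such as an amine, a methyl ester or a longer chain ending in a carboxylic acid. With a single substituted example, they also leave open whether any group on this phenyl ring can move the number beyond the scatter in either direction.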